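The compounds below may be only part of what the source reports. "The series", "measured", "known", "first", "only" and "open" are said of these compounds alone.

Of the compounds shown here, three sharing a common core have been measured in a functional assay on DU-145 cells (Homo sapiens) for cytotoxicity, read by trypan blue exclusion, with a stated time of 96 h; a lower number here means a stronger inhibitor, a higher number a weaker inhibitor. Compound 1 `COc1ccc(/C=C/S(=O)(=O)Nc2ccc(OC)c(F)c2)cc1` gives 5000 nM in this assay. Compound 2 `COc1ccc(NS(=O)(=O)/C=C/c2c(F)cc(F)cc2F)cc1` gives 75000 nM. Compound 3 `COC(=O)C(Nc1cc(NS(=O)(=O)/C=C/c2c(OC)cc(OC)cc2OC)ccc1OC)c1ccccc1` gives 2500 nM, the lowest of the three numbers; its gap to compound 1 lies within the usual scatter of repeated measurements, while its gap to compound 2 lies well beyond it.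

Compound 4 `COc1cc(OC)c(/C=C/S(=O)(=O)Nc2ccc(OC)c(NC(C(=O)O)c3ccc(Br)cc3)c2)c(OC)c1` has not yet been measured in this assay. It differs from compound 3 in one place: (4-bromophenyl)(carboxy)methyl in place of methoxycarbonyl)(benzyl on a nitrogen on an aromatic ring. The change keeps the same number of heavy atoms and keeps one aromatic ring, while exchanging the methoxycarbonyl for a carboxy group and bringing in a bromine.

No measured pair among these compounds makes a change of this kind, so its effect is not known from the data at hand. The expectation is a step of a 1.4-fold higher number from compound 3 to compound 4 (0.15 log units; within the scatter) that stays within the scatter. Compound 4 is therefore expected to give about 3500 nM in this assay, with a likely range from 1200 nM to 10000 nM.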

Compound 4, half-maximal inhibitory concentration: 250 nM
The estimate for compound 4 lay 14-fold (1.15 log units) above the measured number, outside the stated range (below it).
By their numbers in this assay, from the lowest: compound 4; then compounds 3 and 1 (each within the scatter of the next); then compound 2.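

In this assay, going by these compounds alone, replacing methoxycarbonyl)(benzyl with (4-bromophenyl)(carboxy)methyl on a nitrogen on an aromatic ring gives a 10-fold lower number from compound 3 to compound 4 (1.00 log units; beyond the scatter), so this place on the shared core can move the number well beyond the scatter, something the earlier compounds could not show because no two of them differed in one place alone. This single step exchanges the methoxycarbonyl for a carboxy group and also brings in a bromine, so it cannot be divided between those two changes. Nothing in the data at hand accounts for the size of this step.

Still open, from the compounds shown here alone, is whether the carboxy group without the bromine, or the bromine with the methoxycarbonyl kept, would give a similar number. Going by these compounds, it is also open how a chlorine in place of the bromine, or a primary amide in place of the carboxylic acid, would fare at this place.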